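Methyl Added to a Chlorinated Analogue Series

The compounds below may be only part of what the source reports. "The series", "measured", "known", "first", "only" and "open" are said of these compounds alone.

The shared core is a benzothiazole-type scaffold carrying an aminophenyl group; compound 1 `Nc1ccc(-c2nc3ccccc3s2)c(I)c1`, compound 2 `Cc1ccc2nc(-c3ccc(N)cc3I)sc2c1`, compound 3 `Nc1ccc(-c2nc3ccccc3s2)c(Cl)c1` and the as yet unmeasured compound 4 `Cc1cc(N)cc(Cl)c1-c1nc2ccccc2s1` all belong to it. In a functional assay on MCF7 cells (Homo sapiens) for inhibition (on this read-out lower numbers stand for stronger inhibition and higher numbers for weaker inhibition), compound 1 gives < 0.1 nM, which is a limit of the assay and not a number. In this assay compound 2 gives < 0.1 nM, again a limit. Compound 3 likewise gives < 0.1 nM, a limit as well.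

The change from compound 1 to compound 2 is methyl in place of hydrogen on an aromatic carbon, and its step in this assay is a step that the two limits leave unreadable from compound 1 to compound 2. The step cannot be read because every value shown sits at the limit of < 0.1 nM in this assay, at which 3 of the 3 values shown sit. The two cores differ as chloro in place of iodo on an aromatic carbon, with a step that the two limits leave unreadable from compound 1 to compound 3, which is equally unreadable.

The change from compound 3 to compound 4 is methyl in place of hydrogen on an aromatic carbon. It is the same kind of change as that from compound 1 to compound 2, but the surroundings differ: in compound 2 the methyl sits on a ring that is part of a fused or bridged system of two rings, meta to a fused ring and para to a fused ring, whereas in compound 4 it sits ortho to a group of 9 heavy atoms, meta to a chloro group and meta to an amino group.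

With nothing but limits to go on, compound 4 is expected to remain at the limit, a step that the limit leaves unreadable from compound 3 to compound 4 in this assay. The estimate for compound 4 is 0.05 nM.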

Compound 4, half-maximal inhibitory concentration: < 10 nM
Compound 4: a limit, no number (the forecaster's own chance of this, stated with the estimate: 80%); the middle value does not contradict the limit.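

In this assay compound 4 gives < 10 nM, which is a limit of the assay and not a number. Compound 3 also stands at a limit, so no step can be read between compound 3 and compound 4. The compounds shown leave open whether methyl in place of hydrogen on an aromatic carbon changes inhibition in this assay at all, and by how much.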